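Shifting the cyanoguanidine pattern along a longer chain

This account rests on a few compounds, and the source may have more. Where it says the series, first, only, none or still open, it means among the compounds named here.

Three compounds share one core and differ only in a small side group and in the length of the chain that carries it. Compound 1 `CN(C)/C(=N/CCCCn1nc(-c2ccccc2)ccc1=O)NC#N` and compound 2 `CC/N=C(/NC#N)NCCCCn1nc(-c2ccccc2)ccc1=O` carry their group on a chain of the same length, while compound 3 `CC/N=C(/NC#N)NCCCCCn1nc(-c2ccccc2)ccc1=O` carries the group of compound 2 on a longer chain. All three were tested in a functional assay on the whole organism with Rattus norvegicus as the target; on this read-out lower numbers stand for an effect already at smaller amounts and higher numbers for an effect only at larger amounts of compound. In this assay compound 1 gives 52.9 mg/kg, compound 2 gives 60.7 mg/kg, and compound 3 gives 60.3 mg/kg.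

The change from compound 2 to compound 1 is a group of 8 heavy atoms (4 carbon, 4 nitrogen; no ring) in place of a group of 8 heavy atoms (4 carbon, 4 nitrogen; no ring), on a saturated chain carbon, four bonds along the chain from an aromatic nitrogen. It produced a 1.1-fold lower number from compound 2 to compound 1 (0.06 log units; within the scatter), so the two numbers cannot be told apart. The difference between the cores of compound 2 and compound 3 is not broken down here; their values are also within the scatter of each other.

Compound 4 `CN(C)/C(=N/CCCCCn1nc(-c2ccccc2)ccc1=O)NC#N` has not been measured. It differs from compound 3 by a group of 8 heavy atoms (4 carbon, 4 nitrogen; no ring) in place of a group of 8 heavy atoms (4 carbon, 4 nitrogen; no ring), on a saturated chain carbon, five bonds along the chain from an aromatic nitrogen. Among the compounds with values here, this is the same kind of change as the one from compound 2 to compound 1, but the place differs: four bonds along the chain from an aromatic nitrogen in the earlier pair, five bonds along the chain in this one. Because a 1.1-fold lower number from compound 2 to compound 1 (0.06 log units; within the scatter) stayed within the scatter, the step from compound 3 to compound 4 is expected to be small. The expected step is a 1.1-fold lower number from compound 3 to compound 4 (0.04 log units; within the scatter). Compound 4 is therefore estimated to give 55 mg/kg, likely between 33 mg/kg and 92 mg/kg.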

Compound 4, dose for half-maximal effect: 53.1 mg/kg
Beside the measured number, compound 4's estimate is 1.0-fold (0.02 log units) above it; measured number inside the range.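

On the core with the longer chain, the exchange of side group gives a 1.1-fold lower number from compound 3 to compound 4 (0.06 log units; within the scatter), so in this assay this change has no effect that can be told from the usual variation between repeated measurements. Set beside the same exchange on the core with the shorter chain, it behaves alike on both cores, so in this small series the lack of a visible effect carried over from one chain length to the other: the same change on two cores in this assay, a 1.1-fold lower number (0.06 log units; within the scatter) from compound 2 to compound 1 and a 1.1-fold lower number (0.06 log units; within the scatter) from compound 3 to compound 4, 1.0-fold (0.00 log units) apart, within the scatter of two such steps This agreement is between two steps that are each too small to read, so it shows only that the change stayed quiet twice, on these two cores and in this one whole-animal read-out, and not that it has a real effect of a fixed size that transfers from core to core.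

The compounds shown leave open whether any part of this side group matters for the dose needed, since an amine, a carboxylic acid or a urea in place of the cyanoguanidine would test that more sharply than this exchange does. They also leave open whether a shorter chain or a much longer chain would move the number at all, and whether the exchange would stay as quiet on such a chain.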